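The source may hold more compounds than are shown below. What is called first, only, known or untested is meant among the compounds shown, and "the series" means these compounds.

Measured compounds:
compound 1 `C/C(=N\Nc1nc(-c2ccc(Br)cc2)cs1)c1cc2ccccc2o1` with 45200 nM
compound 2 `C/C(=N\Nc1nc(-c2ccc(C)cc2)cs1)c1cc2ccccc2o1` with 21400 nM
compound 3 `C/C(=N\Nc1nc(-c2ccccc2)cs1)c1cc2ccccc2o1` with 16700 nM

All three were run in a functional assay on PC-3 cells (Homo sapiens) for antiproliferative activity; a higher number here means a weaker inhibitor, a lower number a stronger inhibitor. Compound 3 has the lowest of the three numbers; its nearest neighbour is compound 2, and the two lie within the scatter of each other (a 1.3-fold lower number from compound 2 to compound 3 (0.11 log units; within the scatter)), so no order between them can be claimed. Compound 1 stands furthest from it (a 2.7-fold lower number from compound 1 to compound 3 (0.43 log units; beyond the scatter)), and the step of a 2.1-fold lower number from compound 1 to compound 2 (0.32 log units; beyond the scatter) is of similar modest size.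

Compound 4 `CCOC(=O)Cc1csc(N/N=C(\C)c2cc3ccccc3o2)n1` differs from compound 3 by (ethoxycarbonyl)methyl in place of phenyl on an aromatic carbon. Going by the values given here, none of the measured steps touch this position: each of them changed only a substituent on the phenyl that now leaves altogether. What the series shows is that the variations tried so far moved this assay only modestly. For compound 4 the step of a 1.3-fold higher number from compound 3 to compound 4 (0.12 log units; within the scatter) is therefore expected to be small, most likely within the scatter, with a wide range of uncertainty. Compound 4 is estimated at 22000 nM, between 6000 nM and 70000 nM.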

Compound 4, half-maximal inhibitory concentration: 13100 nM
Compound 4: middle estimate off by 1.7-fold (0.23 log units), on the high side; the measured number falls inside the stated range.
By their numbers in this assay, from the lowest: compounds 4, 3 and 2 (each within the scatter of the next); then compound 1.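

In this assay, the phenyl on the aromatic carbon next to the ring nitrogen can give way entirely to the ringless (ethoxycarbonyl)methyl with no readable change (a 1.3-fold lower number from compound 3 to compound 4 (0.11 log units; within the scatter)). The comparison with the 4-methylphenyl compound also stays within the scatter (a 1.6-fold lower number from compound 2 to compound 4 (0.21 log units; within the scatter)), and only the 4-bromophenyl compound stands apart (a 3.5-fold lower number from compound 1 to compound 4 (0.54 log units; beyond the scatter)), so among these compounds an aromatic ring at this position is not needed to keep the number at this level. No measurement shown explains this tolerance.

As far as these compounds go, whether the ester itself matters remains open: a carboxylic acid, a primary amide or a plain propyl chain at this position would test that. From the compounds shown here alone, it is also open whether any group here, such as a basic amine on a longer chain, can move the number far from this range.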